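Pyridin-4-yl to 4-fluorophenyl on a saturated ring carbon

A few compounds are considered here, and "the series" means these few. Any claim that something is new, unique, unknown or untested is made for them only; others in the source may bear on it.

Going by the values given here, in a physicochemical assay for lipophilicity, at pH 7.4 (a lower number here means a more polar compound, a higher number a more lipophilic compound), compound 2 (`CNC(=O)c1cc(C(=O)N[C@H]2[C@@H]3COC[C@@H]32)cc2c1OC[C@H]2c1ccncc1`) gives 1.3 and stands lower of the two numbers so far, with compound 1 (`CNC(=O)c1cc(C(=O)N[C@H]2[C@@H]3COC[C@@H]32)cc2c1OC[C@H]2c1cccc2[nH]ccc12`) at 3.1 as the only other value. Compound 3 (`CNC(=O)c1cc(C(=O)N[C@H]2[C@@H]3COC[C@@H]32)cc2c1OC[C@H]2c1ccc(F)cc1`) has 4-fluorophenyl in place of pyridin-4-yl on a saturated ring carbon. Among the compounds with values here, the only measured step bearing on this is a number 1.80 log units lower from compound 1 to compound 2 (beyond the scatter) (large, beyond the scatter), with pyridin-4-yl in place of 1H-indol-4-yl. In this assay the expected change is a number 1.40 log units higher from compound 2 to compound 3 (beyond the scatter) and thus upward, a large step though smaller than the measured one. The estimate for compound 3 is 2.7 (expected range 2.3 to 3.1).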

Compound 3, distribution coefficient: 3.6
Compound 3: the middle estimate sits 0.90 log units below what was measured; measured number outside the range, above it.
By their numbers in this assay, from the lowest: compound 2; then compound 1; then compound 3.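

At this saturated ring carbon, exchanging pyridin-4-yl for 4-fluorophenyl moves this assay sharply: a number 2.30 log units higher from compound 2 to compound 3 (beyond the scatter). The top of the range is not set by 1H-indol-4-yl, since 4-fluorophenyl exceeds it: a number 0.50 log units higher from compound 1 to compound 3 (beyond the scatter). No available evidence accounts for either step.

Plain phenyl would show how this step divides between loss of the ring nitrogen and gain of the fluorine, and that remains open. Where a carboxylic acid or an amine at this carbon would fall also remains open.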